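Methyl in Place of Chloro on an Aromatic Carbon

A few compounds are considered here, and "the series" means these few. Any claim that something is new, unique, unknown or untested is made for them only; others in the source may bear on it.

Of the compounds shown here, two sharing one core have been measured in a functional assay on PC-3 cells (Homo sapiens) for cytotoxicity, read by sulforhodamine B assay, with a stated time of 48 h; a higher number here means a weaker inhibitor, a lower number a stronger inhibitor. There, compound 1 `C[C@H]1CC[C@@H]2[C@@H](OC(=O)[C@]23CC(c2ccccc2Br)=NO3)[C@]2(C)C(=O)C=C[C@@]12O` gives 51000 nM and compound 2 `C[C@H]1CC[C@@H]2[C@@H](OC(=O)[C@]23CC(c2ccccc2Cl)=NO3)[C@]2(C)C(=O)C=C[C@@]12O` gives 12000 nM, the lower of the two numbers. A third member of the series, compound 3 `Cc1ccccc1C1=NO[C@]2(C1)C(=O)O[C@@H]1[C@H]2CC[C@H](C)[C@]2(O)C=CC(=O)[C@@]12C`, has yet to be measured. It differs from compound 2 by methyl in place of chloro on an aromatic carbon, ortho to a large group.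

Among the compounds with values here, no measured step involves methyl. Within the data shown here, the only guide is the swap of chloro in place of bromo on an aromatic carbon, which gave a 4.3-fold lower number from compound 1 to compound 2 (0.63 log units; beyond the scatter), a modest step beyond the scatter. It shows that a single replacement on this aromatic carbon can shift the number, but it does not fix the direction for methyl. A step of that size or smaller is therefore expected, with a slightly higher number the more likely outcome. In this assay the expected change is a 1.5-fold higher number from compound 2 to compound 3 (0.18 log units; within the scatter), which stays within the scatter. For compound 3 the estimate is 18000 nM, with an expected range from 6000 nM to 50000 nM.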

Compound 3, half-maximal inhibitory concentration: 10000 nM
Beside the measured number, compound 3's estimate is 1.8-fold (0.26 log units) above it; the range from low to high includes it.
By their numbers in this assay, from the lowest: compounds 3 and 2 (each within the scatter of the next); then compound 1.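

In this assay, methyl in place of chloro gave a 1.2-fold lower number from compound 2 to compound 3 (0.08 log units; within the scatter), a step within the scatter, so on this aromatic carbon, ortho to a large group, the assay does not separate these two groups, and a halogen is shown not to be needed to reach the level of compound 2. Methyl in place of bromo gave a 5.1-fold lower number from compound 1 to compound 3 (0.71 log units; beyond the scatter), a modest step beyond the scatter, so compound 1 now stands apart from both other compounds, and bromo is the only one of the three groups that gives a clearly higher number in this series. No measurement shown here accounts for this pattern among the three groups.

The compounds shown carry only bromo, chloro and methyl at this position, so it remains open whether a methoxy group, an amine, a carboxylic acid or a longer chain would stay at the level of compound 2 and compound 3 or move away from it. They also leave open how the ring without any such group would read, and whether the same groups would behave alike on another carbon of the aromatic ring.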